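Changing the Group on the Carbonyl of a Shared Core

The source may hold more compounds than are shown below. What is called first, only, known or untested is meant among the compounds shown, and "the series" means these compounds.

Compound 1 `O=C(N1CCC(F)CC1)N1CC(c2nc(-c3cccc(Cl)c3)no2)C1` gives 990 nM in an assay on HEK293 cells for positive allosteric modulation of metabotropic glutamate receptor 5 (Homo sapiens), read by FLIPR; on this read-out lower numbers stand for an effect already at smaller amounts and higher numbers for an effect only at larger amounts of compound. Compound 2 `O=C(c1cccc(F)c1)N1CC(c2nc(-c3cccc(Cl)c3)no2)C1` reaches only the limit of > 10000 nM in this assay. Compound 3 `CC1CCN(C(=O)N2CC(c3nc(-c4cccc(Cl)c4)no3)C2)C1` likewise reaches only the limit of > 10000 nM in this assay.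

Compound 3 therefore stands at the upper limit of this assay, where compound 2 also sits (the limit of > 10000 nM in this assay, at which 2 of the 3 values shown sit). Compound 4 `O=C(C1CCC2(CCC2)CC1)N1CC(c2nc(-c3cccc(Cl)c3)no2)C1` differs from compound 3 in one place: a group of 9 heavy atoms (9 carbon; one four-membered non-aromatic ring of carbon only, one six-membered non-aromatic ring of carbon only) in place of a group of 6 heavy atoms (5 carbon, 1 nitrogen; one five-membered non-aromatic ring with 1 hetero atom), on a carbonyl carbon. Within the data shown here, the measured steps that bear on such exchanges on the carbonyl carbon are an at least 10-fold higher number from compound 1 to compound 3 (1.00 log units; beyond the scatter) and an at least 10-fold higher number from compound 1 to compound 2 (1.00 log units; beyond the scatter), both leaving the limit as the only reading. The step that the two limits leave unreadable from compound 2 to compound 3 stays unreadable, since both ends are limits. With compound 3 at a limit, any step to compound 4 can only be read if compound 4 returns a number; given that compound 2, which also carries a carbon group on the carbonyl, gave > 10000 nM, an effect only at large amounts is expected. Compound 4 is therefore estimated at 9000 nM, within 1500 nM to 40000 nM, which means an expected step of an at least 1.1-fold lower number from compound 3 to compound 4 (0.04 log units; that floor lies within the scatter).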

Compound 4, half-maximal effective concentration: 1100 nM
Estimate against measurement, compound 4: 8.2-fold (0.91 log units) above, outside the stated range (below it).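

Compound 4 shows that in this assay a group on the carbonyl carbon can give a measured number without any nitrogen, which the 3-fluorophenyl group of compound 2 did not show, since that compound reached only a limit of the assay. The group of 9 carbon atoms brings an at least 9.0-fold lower number from compound 3 to compound 4 (0.95 log units; beyond the scatter) and an at least 9.0-fold lower number from compound 2 to compound 4 (0.95 log units; beyond the scatter), both steps counted from a limit rather than from a number. Against the 4-fluoropiperidin-1-yl group there is a 1.1-fold higher number from compound 1 to compound 4 (0.05 log units; within the scatter), so these two quite different groups cannot be told apart here.

The compounds shown leave open whether both rings of the new group are needed, which a plain cyclohexyl group on the carbonyl carbon would help to settle. On these data alone, it also remains open how an amine or a carboxylic acid on that group would fare.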